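Replacing 4-methoxyphenyl with 3-chlorophenyl on the benzylic arm

This account rests on a few compounds, and the source may have more. Where it says the series, first, only, none or still open, it means among the compounds named here.

compound 1 `O=S(=O)(NCCCNCc1ccc(Cl)c(C(F)(F)F)c1)c1cc(C(F)(F)F)cc(C(F)(F)F)c1` gives 5900 nM in a functional assay on A2780 cells (Homo sapiens) for inhibition, read by MTT assay, with a stated time of 72 h; a lower number here means a stronger inhibitor of growth, a higher number a weaker inhibitor of growth
compound 2 `O=S(=O)(NCCCNCc1cccc2ccccc12)c1cc(C(F)(F)F)cc(C(F)(F)F)c1` gives 3100 nM
compound 3 `COc1ccc(CNCCCNS(=O)(=O)c2cc(C(F)(F)F)cc(C(F)(F)F)c2)cc1` gives 1700 nM

Compound 3 stands at the low end of the three: its gap to compound 1 is beyond the scatter, while compound 2 lies within the scatter of it. Compound 4 `O=S(=O)(NCCCNCc1cccc(Cl)c1)c1cc(C(F)(F)F)cc(C(F)(F)F)c1` is not yet measured and differs from compound 3 in one place: 3-chlorophenyl in place of 4-methoxyphenyl on a saturated chain carbon bound to an amine nitrogen. Among the compounds with values here, two measured steps bear on this, since each also exchanges the group on that chain carbon. a 3.5-fold lower number from compound 1 to compound 3 (0.54 log units; beyond the scatter) shows that the 4-chloro-3-(trifluoromethyl)phenyl of compound 1 gave the higher number, whereas a 1.8-fold lower number from compound 2 to compound 3 (0.26 log units; within the scatter) did not separate beyond the scatter. Compound 4 is therefore expected to give a somewhat higher number in this assay, a 1.8-fold higher number from compound 3 to compound 4 (0.25 log units; within the scatter), a step that may still fall within the scatter. The estimate for compound 4 is 3000 nM, ranging from 1400 nM to 6500 nM.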

Compound 4, concentration for 50% growth inhibition: 2200 nM
The estimate for compound 4 lay 1.4-fold (0.13 log units) above the measured number, and the stated range covers the measured number.
By their numbers in this assay, from the lowest: compounds 3, 4, 2 and 1 (each within the scatter of the next, the first and the last beyond it).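

In this assay, compound 4 cannot be told apart from the 4-methoxyphenyl and naphthalen-1-yl compounds: a 1.3-fold higher number from compound 3 to compound 4 (0.11 log units; within the scatter) and a 1.4-fold lower number from compound 2 to compound 4 (0.15 log units; within the scatter). A chlorine-bearing ring therefore need not give the higher number of compound 1, and a 2.7-fold lower number from compound 1 to compound 4 (0.43 log units; beyond the scatter) is a modest step. Nothing here explains these differences. As far as these compounds go, whether a cyclohexyl group, or a phenyl ring carrying a carboxylic acid, on that chain carbon would shift the number stays open.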